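Dropping One Chloro from the Dichlorophenyl Ring

This account rests on a few compounds, and the source may have more. Where it says the series, first, only, none or still open, it means among the compounds named here.

The series shares one core and varies only the aryl group on the carbon with a double bond to nitrogen. In a functional assay on DU-145 cells (Homo sapiens) for cytotoxicity, read by sulforhodamine B assay, with a stated time of 48 h (on this read-out lower numbers stand for stronger inhibition and higher numbers for weaker inhibition), compound 1 `C[C@H]1CC[C@@H]2[C@@H](OC(=O)[C@]23CC(c2c(Cl)cccc2Cl)=NO3)[C@]2(C)C(=O)C=C[C@@]12O` gives 38000 nM, the second highest of the three numbers measured. Compound 2 `C[C@H]1CC[C@@H]2[C@@H](OC(=O)[C@]23CC(c2ccc(N(C)C)cc2)=NO3)[C@]2(C)C(=O)C=C[C@@]12O` gives 4500 nM in this assay, and compound 3 `COc1ccc(C2=NO[C@]3(C2)C(=O)O[C@@H]2[C@H]3CC[C@H](C)[C@]3(O)C=CC(=O)[C@@]23C)cc1OC` gives 84000 nM. The aryl swaps gave an 8.4-fold lower number from compound 1 to compound 2 (0.93 log units; beyond the scatter), a 2.2-fold higher number from compound 1 to compound 3 (0.34 log units; beyond the scatter) and a 19-fold higher number from compound 2 to compound 3 (1.27 log units; beyond the scatter).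

Compound 4 `C[C@H]1CC[C@@H]2[C@@H](OC(=O)[C@]23CC(c2ccccc2Cl)=NO3)[C@]2(C)C(=O)C=C[C@@]12O` differs from compound 1 in one place: hydrogen in place of chloro on an aromatic carbon. For the measured compounds named here, no measured step removes a single chloro; the three measured steps exchange the whole aryl group, and all stay within a moderate span around compound 1. The change to compound 4 is smaller than any of them, so a step no larger than modest is expected, with the direction uncertain. Compound 4 is estimated at 30000 nM in this assay, with a range of 10000 nM to 90000 nM, meaning an expected step of a 1.3-fold lower number from compound 1 to compound 4 (0.10 log units; within the scatter).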

Compound 4, half-maximal inhibitory concentration: 19000 nM
For compound 4 the middle estimate is 1.6-fold (0.20 log units) above the measured one; low and high end bracket the measured number.
By their numbers in this assay, from the lowest: compound 2; then compounds 4 and 1 (each within the scatter of the next); then compound 3.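

Going from the 2,6-dichlorophenyl group of compound 1 to the 2-chlorophenyl group of compound 4 gives no resolved change in this assay (a 2.0-fold lower number from compound 1 to compound 4 (0.30 log units; within the scatter)), so on this read-out one chloro on this ring can give way to hydrogen without a step beyond the scatter. Compound 4 also keeps the place of compound 1 among the other aryl groups, with a 4.4-fold lower number from compound 3 to compound 4 (0.65 log units; beyond the scatter) on one side and a 4.2-fold higher number from compound 2 to compound 4 (0.63 log units; beyond the scatter) on the other. Nothing available explains these steps.

The compounds shown leave open whether the remaining chloro can also give way to hydrogen, leaving a plain phenyl group. They also leave open how a fluoro or a methyl group would read in the place of that chloro.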